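This account rests on a few compounds, and the source may have more. Where it says the series, first, only, none or still open, it means among the compounds named here.

Working notes on the series

The shared core is that of compound 1, `C=C(C)C(=O)NC(=O)NC1=CS(=O)(=O)O[C@@]12[C@@H](CO[Si](C)(C)C(C)(C)C)O[C@@H](n1cc(C)c(=O)n(C)c1=O)[C@@H]2O[Si](C)(C)C(C)(C)C`. In a functional assay on HEL cells (Homo sapiens) (a lower number here means that less compound is tolerated, a higher number that more compound is tolerated), compound 1 gives 1200 nM; this is the only number shown in this assay. Compound 2, `Cc1cn([C@@H]2O[C@H](CO[Si](C)(C)C(C)(C)C)[C@@]3(OS(=O)(=O)C=C3NC(=O)NC(=O)c3ccccc3)[C@H]2O[Si](C)(C)C(C)(C)C)c(=O)n(C)c1=O`, carries phenyl in place of 1-methylethenyl on a carbonyl carbon. In this assay compound 2 reaches only a limit, >= 200000 nM. The step is an at least 160-fold higher number from compound 1 to compound 2 (2.22 log units; beyond the scatter), resting on (the limit of >= 200000 nM in this assay, at which 1 of the 2 values shown sits).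

Compound 3, `COC(=O)CCNC1=CS(=O)(=O)O[C@@]12[C@@H](CO[Si](C)(C)C(C)(C)C)O[C@@H](n1cc(C)c(=O)n(C)c1=O)[C@@H]2O[Si](C)(C)C(C)(C)C`, is not yet measured. Against compound 1 the change reads: 2-(methoxycarbonyl)ethyl in place of ((1-methylethenyl)carbonyl)carbamoyl on an amine nitrogen. For the measured compounds named here, the single measured step bears on it only in part: both changes touch the ((1-methylethenyl)carbonyl)carbamoyl group, but in compound 3 that whole group leaves and 2-(methoxycarbonyl)ethyl enters on the amine nitrogen. Going by the values given here, since the one measured change, an at least 160-fold higher number from compound 1 to compound 2 (2.22 log units; beyond the scatter), was large and ran toward a higher number, compound 3 is expected to move the same way, with an expected step of a 42-fold higher number from compound 1 to compound 3 (1.62 log units; beyond the scatter). Compound 3 is therefore estimated at 50000 nM, ranging from 8000 nM to 200000 nM, with a fair chance that this assay again reports only a limit.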

Compound 3, half-maximal cytotoxic concentration: 94000 nM
Compound 3: middle estimate off by 1.9-fold (0.27 log units), on the low side, and the stated range covers the measured number.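

Working from this assay, the step to compound 3 shows that the low number of compound 1 does not survive loss of the whole ((1-methylethenyl)carbonyl)carbamoyl group from the amine nitrogen: the change gives a 78-fold higher number from compound 1 to compound 3 (1.89 log units; beyond the scatter). Since compound 2 keeps the carbamoyl link and compound 3 does not, yet both lie far above compound 1, the carbamoyl link alone does not go with the low number among these compounds, and the 1-methylethenyl group is found only in compound 1. The step between the two higher compounds is an at least 2.1-fold lower number from compound 2 to compound 3 (0.32 log units; beyond the scatter), and compound 2 stands at a limit, so this step gives only a bound and not a size: the limit of >= 200000 nM in this assay, at which 1 of the 3 values shown sits.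

Still open, as far as these compounds go, is whether the low number follows the double bond of the 1-methylethenyl group, which a saturated 1-methylethyl group on the same carbonyl carbon would test. Also open, from the compounds shown here alone, is whether the methyl ester of the 2-(methoxycarbonyl)ethyl group matters on the amine nitrogen, where the free carboxylic acid or a plain propyl chain would separate the ester from the chain.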